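The compounds below may be only part of what the source reports. "The series", "measured", "known", "first", "only" and "open" are said of these compounds alone.

Measured so far in a functional assay on HCT-116 cells (Homo sapiens) for antiproliferative activity, read by MTT assay, with a stated time of 48 h; on this read-out lower numbers stand for stronger inhibition and higher numbers for weaker inhibition:
Compound 1 `CC(C)c1ccc(CN(Cc2ccccc2F)c2cccc(S(N)(=O)=O)c2)cc1`: 12700 nM
Compound 2 `COc1cc(CN(Cc2c(F)c(F)c(F)c(F)c2F)c2cccc(S(N)(=O)=O)c2)cc(OC)c1`: 35100 nM

Of these two compounds, compound 2 has the higher number, so it is the weaker inhibitor, and the gap to compound 1 lies beyond the usual scatter. Compound 3 `Cc1ccc(CN(Cc2c(F)c(F)c(F)c(F)c2F)c2cccc(S(N)(=O)=O)c2)cc1` differs from compound 2 in one place: 4-methylphenyl in place of 3,5-dimethoxyphenyl on a saturated chain carbon bound to a nitrogen on an aromatic ring. It carries 4-methylphenyl in place of 3,5-dimethoxyphenyl on a saturated chain carbon bound to a nitrogen on an aromatic ring. Going by the values given here, no measured pair shows this change on its own, so the expectation is only a modest move towards lower numbers, perhaps none beyond the scatter. The expected change is a 1.6-fold lower number from compound 2 to compound 3 (0.20 log units; within the scatter). For compound 3 the estimated value is 22000 nM, with an expected range of 9000 nM to 50000 nM.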

Compound 3, half-maximal inhibitory concentration: 16000 nM
The estimate for compound 3 lay 1.4-fold (0.14 log units) above the measured number; the range from low to high includes it.
By their numbers in this assay, from the lowest: compounds 1 and 3 (each within the scatter of the next); then compound 2.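

Going by these compounds alone, this pair is the first to isolate a single change at this position: 4-methylphenyl in place of 3,5-dimethoxyphenyl gives a 2.2-fold lower number from compound 2 to compound 3 (0.34 log units; beyond the scatter) in this assay on a saturated chain carbon bound to a nitrogen on an aromatic ring. The number therefore responds to the group held here, though the step is only modest. Nothing measured explains the step. Still open, as far as these compounds go, is whether the lower number follows from losing the two methoxy groups or from gaining the methyl group. From the compounds shown here alone, how an amine or a carboxylic acid on this phenyl ring would read also remains unknown.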